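Swapping Cyclopentylamino for Hexyloxy: Expected Cytotoxicity

The compounds below may be only part of what the source reports. "The series", "measured", "known", "first", "only" and "open" are said of these compounds alone.

Measured compounds and their values:
- Compound 1, `CCCCCCCCOc1nc(N)nc2c1ncn2/C=C1/CC1(CO)CO`, in an ADME assay on MOLT-3 cells (Homo sapiens) for cytotoxicity, with a stated time of 7 days (on this read-out lower numbers stand for higher toxicity in this test and higher numbers for lower toxicity in this test), gives > 20000 nM, which is a limit of the assay and not a number.
- Compound 2, `CCCCSc1nc(N)nc2c1ncn2/C=C1/CC1(CO)CO`, in this assay gives > 20000 nM, again only a limit.
- Compound 3, `Nc1nc(NC2CCCC2)c2ncn(/C=C3/CC3(CO)CO)c2n1`, in this assay gives > 20000 nM, also a limit.

Compound 3 thus stands where every measured compound stands: at the limit of > 20000 nM in this assay, at which 3 of the 3 values shown sit. For the measured compounds named here, no compound in this set shows a readable number, so none can be called more or less toxic than another.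

The next compound, compound 4, `CCCCCCOc1nc(N)nc2c1ncn2/C=C1/CC1(CO)CO`, differs from compound 3 in one place: hexyloxy in place of cyclopentylamino on an aromatic carbon. Going by the values given here, three measured steps touch the same position on the shared core: a step that the two limits leave unreadable from compound 1 to compound 3, a step that the two limits leave unreadable from compound 2 to compound 3 and a step that the two limits leave unreadable from compound 1 to compound 2. Among the compounds with values here, each of them joins two limits, so their sizes cannot be read, and they tell only that changing this side group among octyloxy, butylsulfanyl and cyclopentylamino left the read-out at the limit.

Because of the limit of > 20000 nM in this assay, at which 3 of the 3 values shown sit, the expected step that the limit leaves unreadable from compound 3 to compound 4 is none beyond the scatter, with no direction to expect. Compound 4 is estimated at 30000 nM, with a range from 15000 nM to 100000 nM, and the assay will most likely again report only a limit.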

Compound 4, half-maximal cytotoxic concentration: > 20000 nM
Compound 4 gave a limit, no number; the forecaster's own chance of this, stated with the estimate: 85%; the middle value is on the limit's open side.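

Compound 4 sits at the same assay limit as compound 1, compound 2 and compound 3 in this assay, so none of the steps joining these four compounds can be read: the limit of > 20000 nM in this assay, at which 4 of the 4 values shown sit.

The compounds shown leave open whether these side groups on the shared core differ at all in toxicity, as no readable number separates them.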